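Swapping one five-membered ring on a shared core

The compounds below may be only part of what the source reports. "The series", "measured", "known", "first", "only" and "open" are said of these compounds alone.

Compound 1 (`CCN(c1cccc(-c2ccccc2)c1)c1ccc(C#N)c(Cl)c1`): "not determined" (no result reported)
Compound 2 (`CCN(c1ccc(C#N)c(Cl)c1)c1cc(-c2ccccc2)ccc1C`): "not determined" (no result reported)
Compound 3 (`CCN(c1ccc(C#N)c(Cl)c1)c1cc(-c2ccnn2C)ccc1C`): 7290 nM

Only one of these compounds has a number to work with. In a functional assay on PC-3 cells (Homo sapiens) for antiproliferative activity, read by CCK-8 assay, with a stated time of 6 days (on this read-out lower numbers stand for stronger inhibition and higher numbers for weaker inhibition), compound 3 gives 7290 nM, while compounds 1 and 2 have no reported result. Compound 3 therefore cannot yet be ranked against anything.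

Compound 4 (`CCN(c1ccc(C#N)c(Cl)c1)c1cc(-n2ccnc2)ccc1C`) has not been measured. It carries 1H-imidazol-1-yl in place of 1-methyl-1H-pyrazol-5-yl on an aromatic carbon, para to a methyl group: 1H-imidazol-1-yl in place of 1-methyl-1H-pyrazol-5-yl on an aromatic carbon. Both groups are five-membered aromatic rings, and the rest of the molecule stays the same.

Among the measured compounds shown here, no measured pair in this set shows what such a swap does, so the forecast rests on compound 3 alone (7290 nM). In this assay no direction can be argued, and the expected change is none beyond the scatter: a 1.0-fold higher number from compound 3 to compound 4 (0.01 log units; within the scatter). The uncertainty is wide, since a single value anchors it. Compound 4 is estimated at 7500 nM (expected range 2500 nM to 22000 nM).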

Compound 4, half-maximal inhibitory concentration: > 30000 nM
Compound 4 gave a limit, no number (the forecaster's own chance of this, stated with the estimate: 25%); middle value at least 4.0-fold (0.60 log units) away from the limit.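

In this assay compound 4 gives only a limit of the assay, > 30000 nM, and not a number. Even so, the swap can be sized, and this aromatic carbon, para to a methyl group, does not accept the two five-membered aromatic rings equally, despite their matching hydrogen-bond counts: the result is an at least 4.1-fold higher number from compound 3 to compound 4 (0.61 log units; beyond the scatter). The full size of this step cannot be stated because compound 4 sits at the limit: the limit of > 30000 nM in this assay, at which 1 of the 4 values shown sits.

The compounds shown leave open whether the step comes from attaching the ring through a nitrogen or from losing the methyl group on the ring. They also leave open how a non-ring group, such as an amine or a carboxylic acid, would behave on this same aromatic carbon.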